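Amino in place of methoxy: working notes

This account rests on a few compounds, and the source may have more. Where it says the series, first, only, none or still open, it means among the compounds named here.

Going by the values given here, in a functional assay on HCT-116 cells (Homo sapiens) for antiproliferative activity, read by MTT assay, with a stated time of 48 h (on this read-out higher numbers stand for weaker inhibition and lower numbers for stronger inhibition), compound 1 (`CCCC(CCO)n1cnc2c(Cl)nc(F)nc21`) gives 16500 nM, the only actual number so far. Compound 2 (`CCCCC(CCO)n1cnc2c(Cl)ncnc21`) reports only a limit, > 50000 nM. Compound 3 (`CCCCC(CCO)n1cnc2c(OC)ncnc21`) also reports only a limit, > 50000 nM. Going by these compounds, this places compound 3 at the limit of > 50000 nM in this assay, at which 2 of the 3 values shown sit, so its true value in this assay is unknown.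

The next change gives compound 4 (`CCCCC(CCO)n1cnc2c(N)ncnc21`): amino in place of methoxy on an aromatic carbon. Among the compounds with values here, the only measured step at this place is a step that the two limits leave unreadable from compound 2 to compound 3, methoxy in place of chloro on an aromatic carbon. It offers no size to carry over, and neither of its compounds shows a readable value.

A report at the limit is therefore the likeliest outcome for compound 4, with no direction firmly expected. The estimated change is an at least 1.1-fold lower number from compound 3 to compound 4 (0.04 log units; that floor lies within the scatter). For compound 4 the expected value is 45000 nM, with an estimated range of 15000 nM to 100000 nM.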

Compound 4, half-maximal inhibitory concentration: > 50000 nM
Compound 4 gave a limit, no number; the forecaster's own chance of this, stated with the estimate: 60%; at least 1.1-fold (0.04 log units) between middle value and limit.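

No new step can be read among compound 2, compound 3 and compound 4 in this assay, since all three report only limits: the limit of > 50000 nM in this assay, at which 3 of the 4 values shown sit.

The compounds shown leave open where the true values of these three lie and whether chloro, methoxy and amino differ at this place.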